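Hydroxy added to compound 3

The source may report more compounds than this note shows. Statements on the series, on what has been measured and on what is new or still open speak of the compounds shown alone.

In a functional assay on Bel-7402 cells (Homo sapiens) for antiproliferative activity, read by MTT assay, with a stated time of 72 h (a higher number here means a weaker inhibitor, a lower number a stronger inhibitor), compound 3 (`COc1ccc(Cn2c(C(=O)O)c(CNCc3cccc(OC)c3)c3ccc(C)cc32)cc1`) gives 9830 nM and compound 1 (`COc1ccc(Cn2c(C(=O)O)c(CNCc3ccc(O)c(OC)c3)c3ccc(C(C)C)cc32)cc1`) gives 8380 nM, within the scatter of each other. Compound 2 (`COc1ccc(Cn2c(C(=O)O)c(CNCc3cc(OC)ccc3O)c3ccc(C)cc32)cc1`) gives > 50000 nM, a limit and not a number. Compound 4 (`COc1ccc(Cn2c(C(=O)O)c(CNCc3ccc(O)c(OC)c3)c3ccc(C)cc32)cc1`) differs from compound 3 as follows: hydroxy in place of hydrogen on an aromatic carbon, with the hydroxy ortho to a methoxy group and para to a large group. Going by the values given here, the one measured hydroxy step is an at least 5.0-fold lower number from compound 2 to compound 3 (0.70 log units; beyond the scatter), beyond the scatter, though that hydroxy sits elsewhere. Compound 1 carries the same 4-hydroxy-3-methoxybenzyl group, differs elsewhere on the core, and gives 8380 nM, so only a small rise in this assay is expected. The expected step is a 1.4-fold higher number from compound 3 to compound 4 (0.15 log units; within the scatter). For compound 4 the estimate is 14000 nM, with an expected range of 6000 nM to 40000 nM.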

Compound 4, half-maximal inhibitory concentration: 13300 nM
The estimate for compound 4 lay 1.1-fold (0.02 log units) above the measured number; measured number inside the range.
By their numbers in this assay, from the lowest: compounds 1, 3 and 4 (each within the scatter of the next). At a limit, above all of these: compound 2.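

Hydroxy in place of hydrogen at this position, ortho to the methoxy group, is tolerated in this assay, with a 1.4-fold higher number from compound 3 to compound 4 (0.13 log units; within the scatter), so a ring hydroxy as such does not go with the loss seen for compound 2. Placement does count, with 4-hydroxy-3-methoxyphenyl against 2-hydroxy-5-methoxyphenyl giving an at least 3.7-fold lower number from compound 2 to compound 4 (0.57 log units; beyond the scatter), though this is only a bound, as compound 2 stands at a limit and not a number: the limit of > 50000 nM in this assay, at which 1 of the 4 values shown sits. Methyl and isopropyl on the core read alike, with a 1.6-fold higher number from compound 1 to compound 4 (0.20 log units; within the scatter).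

Open, as far as these compounds go, is whether an amino group or a fluorine at this position would read the same. Also open, from the compounds shown here alone, is whether the 2-hydroxy-5-methoxyphenyl result holds with isopropyl on the core.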